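The source may report more compounds than this note shows. Statements on the series, on what has been measured and on what is new or still open speak of the compounds shown alone.

Measured so far:
Compound 1 `COc1ccccc1S(=O)(=O)/C=C/c1cccnc1` gives 92% in an ADME assay on BV-2 cells (Mus musculus) for cytotoxicity, with a stated time of 24 h, tested at 50 uM; on this read-out higher numbers stand for a weaker effect at the one concentration tested and lower numbers for a stronger effect.
Compound 2 `COc1cccc(S(=O)(=O)/C=C/c2cccnc2)c1` gives 90.8% in this assay.
Compound 3 `COc1ccccc1S(=O)(=O)/C=C/c1ccncc1` gives 78.9% in this assay.

Compound 4 `COc1cccc(S(=O)(=O)/C=C/c2ccncc2)c1` has not yet been measured. It differs from compound 2 by one change: pyridin-4-yl in place of pyridin-3-yl on a double-bonded chain carbon bound to a double-bonded chain carbon. The same change, made on a different core, turns compound 1 into compound 3: pyridin-4-yl in place of pyridin-3-yl on a double-bonded chain carbon bound to a double-bonded chain carbon, and there it made the step of a number 13.1 percentage points lower from compound 1 to compound 3 (beyond the scatter). How the core of compound 1 differs from the core of compound 2 is not broken down here; the two values of compound 1 and compound 2 lie within the usual scatter of each other, so the cores appear to behave alike in this assay. Within the data shown here, on that basis a step of similar size is expected from compound 2 to compound 4, namely a number 12.8 percentage points lower from compound 2 to compound 4 (beyond the scatter), because the one example of this change gave a number 13.1 percentage points lower from compound 1 to compound 3 (beyond the scatter). Compound 4 is therefore estimated at 78%, with a likely range from 68% to 89%.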

Compound 4, a percentage reported as activity, at one concentration (the size of the read-out at that concentration, not a potency): 21.3%
Compound 4: middle estimate off by 56.7 percentage points, on the high side; the whole stated range lies above it.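

In this assay, putting pyridin-4-yl in place of pyridin-3-yl gives a number 69.5 percentage points lower from compound 2 to compound 4 (beyond the scatter), so the change points the same way on both cores but its size does not carry over: the same change on two cores in this assay, a number 13.1 percentage points lower (beyond the scatter) from compound 1 to compound 3 and a number 69.5 percentage points lower (beyond the scatter) from compound 2 to compound 4, 56.4 percentage points apart, beyond the scatter of two such steps

Compound 1 and compound 2 read alike with pyridin-3-yl, yet that likeness did not foretell how each core would respond to the swap. These two pairs show that the size of this step can depend on the core, but they do not show why, or what the step would be on any further core.

Going by these compounds, it remains open whether the two cores would also part ways with a plain phenyl ring in place of the pyridine. The same question applies to an amine or a chlorine in place of the methoxy group.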